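The source may hold more compounds than are shown below. What is called first, only, known or untested is meant among the compounds shown, and "the series" means these compounds.

Measured so far in an assay on isolated protein for inhibition of DNA nucleotidylexotransferase (Homo sapiens), read by scintillation counting, with a stated time of 10 min; a higher number here means a weaker inhibitor, a lower number a stronger inhibitor:
Compound 1 `CCOC(=O)C(=O)CC(=O)/C=C/c1cn(Cc2ccccc2)c2ccccc12` gives only a limit of the assay, > 40 uM.
Compound 2 `CCOC(=O)C(=O)CC(=O)/C=C/c1cn(Cc2ccc(F)cc2)c2ccccc12` gives only a limit of the assay, > 40 uM.
Compound 3 `CCOC(=O)C(=O)CC(=O)/C=C/c1cc(C(=O)c2ccccc2)cn1Cc1ccccc1` gives only a limit of the assay, > 40 uM.

All three values sit at the limit of > 40 uM in this assay, at which 3 of the 3 values shown sit, so none of them is a number and no order among the three compounds can be read. The change from compound 1 to compound 2 is fluoro in place of hydrogen on an aromatic carbon; the step it made, a step that the two limits leave unreadable from compound 1 to compound 2, cannot be read since both of its ends sit at the limit of > 40 uM in this assay, at which 3 of the 3 values shown sit.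

How the core of compound 3 differs from the core of compound 1 is not broken down here. Compound 4 `CCOC(=O)C(=O)CC(=O)/C=C/c1cc(C(=O)c2ccccc2)cn1Cc1ccc(F)cc1` is not yet measured; it differs from compound 3 by fluoro in place of hydrogen on an aromatic carbon, the same change in the same place as from compound 1 to compound 2. In this assay the step from compound 3 to compound 4 is expected to be a step that the limit leaves unreadable from compound 3 to compound 4, an expectation resting on compound 1 and compound 2, which both sit at the limit of > 40 uM in this assay, at which 3 of the 3 values shown sit, and give no readable step. Compound 4 is expected to give about 60 uM, most likely again only a limit, between 25 uM and 200 uM.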

Compound 4, concentration for 50% inhibition: > 40 uM
Compound 4 gave a limit, no number; the forecaster's own chance of this, stated with the estimate: 85%; the middle value does not contradict the limit.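

Compound 3 and compound 4 each give only a limit of the assay, not a number, so the step between them cannot be read: the limit of > 40 uM in this assay, at which 4 of the 4 values shown sit.

The compounds shown leave open whether benzyl to 4-fluorobenzyl changes inhibition at all in this assay, and which structure, if any, would give a measurable value there.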